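Bromo Exchanged for Benzyloxy in a Cytotoxicity Series

The source may report more compounds than this note shows. Statements on the series, on what has been measured and on what is new or still open speak of the compounds shown alone.

Measured so far:
Compound 1, `Cc1ccc(S(=O)(=O)n2cc(-c3cc(C(F)(F)F)ccn3)c3cc(Br)ccc32)cc1`: 4100 nM
Compound 2, `Cc1ccc(S(=O)(=O)n2cc(-c3cc(C(F)(F)F)cc(-c4cn(S(=O)(=O)c5ccc(C)cc5)c5cc(Br)ccc45)n3)c3ccc(Br)cc32)cc1`: > 100000 nM

Of the compounds shown here, two have been tested in a functional assay on A549 cells (Homo sapiens) for cytotoxicity; a higher number here means a weaker inhibitor, a lower number a stronger inhibitor. Going by the values given here, compound 1 gives 4100 nM, the only real number among the two results. Compound 2 reaches only a limit of the assay, > 100000 nM, not a number. Put differently, one of the two results is the limit of > 100000 nM in this assay, at which 1 of the 2 values shown sits. Among the compounds with values here, no pair of measured compounds differs in one place, so no single structural step has a measured size here.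

Compound 3, `Cc1ccc(S(=O)(=O)n2cc(-c3cc(C(F)(F)F)ccn3)c3cc(OCc4ccccc4)ccc32)cc1`, has not been measured. It differs from compound 1 in one change: benzyloxy in place of bromo on an aromatic carbon. Within the data shown here, with no comparable measured step to lean on, the expectation for this assay is a small step, in no clear direction, within the usual scatter of repeated measurements. Compound 3 is therefore expected to give about 5000 nM, in a range from 1500 nM to 20000 nM. The step of a 1.2-fold higher number from compound 1 to compound 3 (0.09 log units; within the scatter) is expected to be small.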

Compound 3, half-maximal inhibitory concentration: > 100000 nM
Compound 3 ended at the assay's limit; the forecaster's own chance of this, stated with the estimate: 10%; middle value at least 20-fold (1.30 log units) from the limit.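

In this assay, going by these compounds alone, the aromatic carbon meta to a fused ring and para to a fused ring proves sensitive to what it carries: benzyloxy in place of bromo gives an at least 24-fold higher number from compound 1 to compound 3 (1.38 log units; beyond the scatter), the only step with a measured size. The value of compound 3 is a limit of the assay and not a number, so this step has a bound rather than an exact size. Most of the results shown now rest on that limit: the limit of > 100000 nM in this assay, at which 2 of the 3 values shown sit.

The compounds shown leave open whether a smaller group on this carbon, such as methoxy, chlorine or an amine, would keep the value of compound 1, 4100 nM. They also do not tell whether the oxygen or the added aromatic ring of benzyloxy carries the step.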